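Urea aryl swap: naphthalen-1-yl on the compound 2 scaffold

The source may report more compounds than this note shows. Statements on the series, on what has been measured and on what is new or still open speak of the compounds shown alone.

Going by the values given here, compound 2 `O=C(Nc1ccc(Nc2ncnc3c2OCCN3)cc1)Nc1ccc(C(F)(F)F)cc1` holds the lower of the two numbers so far in an assay on isolated protein for inhibition of proto-oncogene tyrosine-protein kinase receptor Ret variant V804M (Homo sapiens), read by 33P incorporation, with stated times of 15 min and 40 min (on this read-out higher numbers stand for weaker inhibition and lower numbers for stronger inhibition), giving 276 nM; compound 1 `O=C(Nc1ccc(Br)cc1)Nc1ccc(Nc2ncnc3c2OCCN3)cc1` gives 2350 nM. Among the compounds with values here, the only measured step, an 8.5-fold lower number from compound 1 to compound 2 (0.93 log units; beyond the scatter), concerns a group on the same aryl ring as the present change. Compound 3 `O=C(Nc1ccc(Nc2ncnc3c2OCCN3)cc1)Nc1cccc2ccccc12` differs by naphthalen-1-yl in place of 4-(trifluoromethyl)phenyl on an amide-type nitrogen. Within the data shown here, no measured step tests this exchange, so its size cannot be read from the series; a step of moderate size in either direction is plausible, with the number for compound 3 expected to sit near that of compound 2, as a 1.8-fold higher number from compound 2 to compound 3 (0.26 log units; within the scatter). Compound 3 is estimated at 500 nM, within 150 nM to 2000 nM.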

Compound 3, half-maximal inhibitory concentration: > 10000 nM
Compound 3 gave a limit, no number; the forecaster's own chance of this, stated with the estimate: 3%; middle value at least 20-fold (1.30 log units) away from the limit.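

Naphthalen-1-yl on the amide-type nitrogen gives an at least 36-fold higher number from compound 2 to compound 3 (1.55 log units; beyond the scatter) and an at least 4.2-fold higher number from compound 1 to compound 3 (0.62 log units; beyond the scatter). The earlier compounds shown here showed only a change of substituent on the phenyl ring, whereas this position also responds strongly when the whole aryl group is exchanged. Compound 3 gives a limit rather than a number in this assay: the limit of > 10000 nM in this assay, at which 1 of the 3 values shown sits.

As far as these compounds go, how far compound 3 lies past that limit stays open. Also open, from the compounds shown here alone, is whether the second aromatic ring or the attachment through naphthalen-1-yl drives the step, which naphthalen-2-yl or unsubstituted phenyl at this place would help separate.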